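Ethoxy replacing fluoro on the fused-ring core

The compounds below may be only part of what the source reports. "The series", "measured", "known", "first", "only" and "open" are said of these compounds alone.

Compound 1, `CCOc1ccc2nc(C(=O)Nc3c(F)cc(-c4cccc(F)c4)cc3F)c(C)c(O)c2c1`, gives 2.96% in a functional assay on A-375 cells (Homo sapiens) for antiproliferative activity, read by MTT assay, with a stated time of 24 h, tested at 1.23 ug/mL; on this read-out higher numbers stand for a stronger effect at the one concentration tested and lower numbers for a weaker effect.
Compound 2, `Cc1ccc2nc(C(=O)Nc3c(F)cc(-c4cccc(F)c4)cc3F)c(C)c(C(=O)O)c2c1`, gives 3.65% in this assay.
Compound 3, `Cc1c(C(=O)Nc2c(F)cc(-c3cccc(F)c3)cc2F)nc2ccc(F)cc2c1C(=O)O`, gives 16.3% in this assay.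

Compound 3 stands highest of the three, with compound 2 nearest and compound 1 furthest, both beyond the scatter. Compound 4, `CCOc1ccc2nc(C(=O)Nc3c(F)cc(-c4cccc(F)c4)cc3F)c(C)c(C(=O)O)c2c1`, differs from compound 3 by ethoxy in place of fluoro on an aromatic carbon. Among the compounds with values here, the one measured step at this position, a number 12.7 percentage points higher from compound 2 to compound 3 (beyond the scatter), is modest and ran toward compound 3. The change to compound 4 moves away from fluoro again, and compound 1, which also carries ethoxy, sits low. A modest downward step, a number 10.3 percentage points lower from compound 3 to compound 4 (beyond the scatter), is therefore expected. Compound 4 is expected to give about 6%, within 0% to 16%.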

Compound 4, a percentage reported as inhibition, at one concentration (the size of the read-out at that concentration, not a potency): 26.7%
The estimate for compound 4 lay 20.7 percentage points below the measured number, outside the stated range (above it).
By their numbers in this assay, from the lowest: compounds 1 and 2 (each within the scatter of the next); then compound 3; then compound 4.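

With the carboxy group in place, ethoxy on this aromatic carbon gives the highest reading of the series in this assay, showing a number 10.4 percentage points higher from compound 3 to compound 4 (beyond the scatter) and a number 23.1 percentage points higher from compound 2 to compound 4 (beyond the scatter). Ethoxy alone does not carry that reading, since with ethoxy on both compounds the change of hydroxy to carboxy gives a number 23.7 percentage points higher from compound 1 to compound 4 (beyond the scatter). No measurement shown here offers an explanation for these steps.

On these data alone, what remains open is whether a longer chain such as propoxy, or an amine, on this aromatic carbon would read higher or lower than ethoxy.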